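Chloromethyl for vinyl on the warhead carbonyl

The source may hold more compounds than are shown below. What is called first, only, known or untested is meant among the compounds shown, and "the series" means these compounds.

Compound 1 `CCOC(=O)c1cc(-c2ccc(Oc3ccccc3)cc2)nn1Cc1cccc(NC(=O)CCl)c1` gives 500 nM in a functional assay on Maver1 cells (Homo sapiens) for inhibition, read by luminescence and CellTiter-Glo, with a stated time of 72 h; a lower number here means a stronger inhibitor, a higher number a weaker inhibitor.
Compound 2 `C/C=C/C(=O)Nc1cccc(Cn2nc(-c3ccc(Oc4ccccc4)cc3)cc2CO)c1` gives 8100 nM in this assay.
Compound 3 `C=CC(=O)Nc1cccc(Cn2nc(-c3ccc(Oc4ccccc4)cc3)cc2CO)c1` gives 6700 nM in this assay.

Compound 3 stands second highest of the three numbers. Its nearest neighbour is compound 2, and the step of a 1.2-fold lower number from compound 2 to compound 3 (0.08 log units; within the scatter) is within the scatter. Going by the values given here, compound 1 lies well below it, beyond the scatter, but differs from compound 3 in two places, so its value shows only that a chloromethyl-bearing compound can reach a low number.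

Compound 4 `O=C(CCl)Nc1cccc(Cn2nc(-c3ccc(Oc4ccccc4)cc3)cc2CO)c1` differs from compound 3 by chloromethyl in place of vinyl on a carbonyl carbon. Among the compounds with values here, no measured step shows this change alone; the only measured step, from compound 2 to compound 3, concerns a different change. A moderate drop is expected, a 2.7-fold lower number from compound 3 to compound 4 (0.43 log units; beyond the scatter), and compound 4 is estimated at 2500 nM, between 600 nM and 9000 nM.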

Compound 4, half-maximal inhibitory concentration: 400 nM
For compound 4 the middle estimate is 6.3-fold (0.80 log units) above the measured one; the measured number lies below the stated range.
By their numbers in this assay, from the lowest: compounds 4 and 1 (each within the scatter of the next); then compounds 3 and 2 (each within the scatter of the next).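

In this assay chloromethyl on the carbonyl carbon brings a large drop with the rest of the molecule unchanged, seen as a 17-fold lower number from compound 3 to compound 4 (1.22 log units; beyond the scatter) and, with chloromethyl in place of prop-1-en-1-yl, as a 20-fold lower number from compound 2 to compound 4 (1.31 log units; beyond the scatter) in the same series. With chloromethyl present, the change of ethoxycarbonyl to hydroxymethyl on an aromatic carbon stays within the scatter, as a 1.3-fold lower number from compound 1 to compound 4 (0.10 log units; within the scatter) shows, so ethoxycarbonyl is not needed for the low number. Nothing given here accounts for the size of the drop.

Still open, on these data alone, is whether an amine or a longer chain in place of chloromethyl on the carbonyl carbon would keep the low number, and whether a carboxylic acid in place of hydroxymethyl on the aromatic carbon would.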